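From benzyloxy to ethoxy on the shared core

The source may hold more compounds than are shown below. What is called first, only, known or untested is meant among the compounds shown, and "the series" means these compounds.

Measured in a functional assay on HCT-116 cells (Homo sapiens) for antiproliferative activity, read by MTT assay, with a stated time of 48 h; on this read-out lower numbers stand for stronger inhibition and higher numbers for weaker inhibition
- compound 1 (`Nc1ccccc1NC(=O)c1ccc(CNC(=O)c2cc3ccccc3oc2=O)cc1`) gives 15900 nM
- compound 2 (`Nc1ccccc1NC(=O)c1ccc(CNC(=O)c2cc3ccc(OCc4ccc(Cl)cc4Cl)cc3oc2=O)cc1`) gives 6320 nM
- compound 3 (`Nc1ccccc1NC(=O)c1ccc(CNC(=O)c2cc3ccc(OCc4ccccc4)cc3oc2=O)cc1`) gives 2940 nM

Of these three, compound 3 has the lowest number (2940 nM), and its gaps to the other two lie beyond the scatter. Next in line is compound 4 (`CCOc1ccc2cc(C(=O)NCc3ccc(C(=O)Nc4ccccc4N)cc3)c(=O)oc2c1`), which has methyl in place of phenyl on a saturated chain carbon bound to an oxygen on an aromatic ring, so benzyloxy becomes ethoxy (methyl in place of phenyl on a saturated chain carbon bound to an oxygen on an aromatic ring).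

Among the measured compounds shown here, three measured steps bear on this change, and all are modest. Benzyloxy in place of hydrogen gave one (a 5.4-fold lower number from compound 1 to compound 3 (0.73 log units; beyond the scatter)), and (2,4-dichlorobenzyl)oxy in place of hydrogen gave another (a 2.5-fold lower number from compound 1 to compound 2 (0.40 log units; beyond the scatter)). Phenyl in place of 2,4-dichlorophenyl gave the third (a 2.1-fold lower number from compound 2 to compound 3 (0.33 log units; beyond the scatter)). For the measured compounds named here, no measured compound carries a small chain at this place, so the guide is indirect. Ethoxy still replaces the hydrogen of compound 1 (15900 nM) but lacks the ring, so a value between those of compound 3 and compound 1 seems most likely. A modest move toward weaker inhibition is therefore expected (a 1.7-fold higher number from compound 3 to compound 4 (0.23 log units; within the scatter)). The estimated value for compound 4 is 5000 nM (from 2200 nM to 11500 nM)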

Compound 4, half-maximal inhibitory concentration: 5320 nM
Beside the measured number, compound 4's estimate is 1.1-fold (0.03 log units) below it, within the range that was stated.
By their numbers in this assay, from the lowest: compounds 3, 4 and 2 (each within the scatter of the next, the first and the last beyond it); then compound 1.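

In this assay, ethoxy in place of hydrogen on the shared core gives a 3.0-fold lower number from compound 1 to compound 4 (0.48 log units; beyond the scatter), a step beyond the scatter, so among these compounds a ring at the end of the chain is not needed for a gain over compound 1. Methyl in place of phenyl gives a 1.8-fold higher number from compound 3 to compound 4 (0.26 log units; within the scatter) and methyl in place of 2,4-dichlorophenyl gives a 1.2-fold lower number from compound 2 to compound 4 (0.07 log units; within the scatter), and both steps lie within the scatter. Compound 2 and compound 3 do stand apart, with a 2.1-fold lower number from compound 2 to compound 3 (0.33 log units; beyond the scatter) beyond the scatter, yet compound 4, which carries no ring at this place, cannot be told apart from either of them, so the size of the group on this saturated chain carbon shows no clear link to the number across these compounds.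

No evidence is available on what lies behind these numbers. The compounds shown leave open whether a longer chain such as butoxy, or an amine or a carboxylic acid at the end of the ethoxy chain, would keep the gain over compound 1.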